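A few compounds are considered here, and "the series" means these few. Any claim that something is new, unique, unknown or untested is made for them only; others in the source may bear on it.

Measured so far in a functional assay on CRL2813 cells (Homo sapiens) for cytotoxicity, read by sulforhodamine B assay, with a stated time of 5 days; a higher number here means a weaker inhibitor, a lower number a stronger inhibitor:
compound 1 `O=C(Nc1cccc([N+](=O)[O-])c1)N[C@H]1CC[C@H](Oc2ccc(F)cc2)CC1`: 6700 nM
compound 2 `O=C(Nc1cccc(C(F)(F)F)c1)N[C@H]1CC[C@H](Oc2ccccc2F)CC1`: 2450 nM
compound 3 `O=C(Nc1ccccc1C(=O)O)N[C@H]1CC[C@@H](Oc2ccc(F)cc2)CC1`: > 20000 nM

Compound 1 gives the highest of the two numbers available, and the nearest, compound 2, lies lower by a gap beyond the usual scatter. Compound 3 reaches only a limit of this assay rather than a number (the limit of > 20000 nM in this assay, at which 1 of the 3 values shown sits).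

The next compound, compound 4 `O=C(Nc1ccccc1Br)N[C@H]1CC[C@H](Oc2ccc(F)cc2)CC1`, differs from compound 1 in one place: 2-bromophenyl in place of 3-nitrophenyl on an amide-type nitrogen. For the measured compounds named here, no measured pair shows this kind of change, so the size of the step can only be guessed. Compound 4 is expected to land near 4000 nM, within a range from 1500 nM to 12000 nM. That estimate implies a modest step from compound 1 to compound 4 of a 1.7-fold lower number from compound 1 to compound 4 (0.22 log units; within the scatter), which may or may not exceed the scatter.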

Compound 4, half-maximal inhibitory concentration: 7700 nM
Compound 4: the middle estimate sits 1.9-fold (0.28 log units) below what was measured, within the range that was stated.
By their numbers in this assay, from the lowest: compound 2; then compounds 1 and 4 (each within the scatter of the next). At a limit, above all of these: compound 3.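

For the compounds shown here, putting 2-bromophenyl in place of 3-nitrophenyl on the amide-type nitrogen gives a 1.1-fold higher number from compound 1 to compound 4 (0.06 log units; within the scatter) in this assay, the only direct comparison at this place so far. On this one pair, the nitro group and its hydrogen-bond acceptors can be lost with no change beyond the scatter. Nothing available explains why the two compounds match.

Still open, going by these compounds, is whether an amine or a longer alkyl chain in place of these phenyl groups on the amide-type nitrogen would keep the number. Also open, on these data alone, is whether any change at this place can move it beyond the scatter.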